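Sulfonate esters of cyclic ureas tested against HT-29 cells

A few compounds are considered here, and "the series" means these few. Any claim that something is new, unique, unknown or untested is made for them only; others in the source may bear on it.

Compound 1 `COc1ccc(OS(=O)(=O)c2ccc(N3CCN(C)C3=O)cc2)cc1OC`: 12000 nM
Compound 2 `CCN1CCN(c2ccc(S(=O)(=O)Oc3ccc(OC)c(OC)c3)cc2)C1=O`: 37000 nM
Compound 3 `CCCN1CCN(c2ccc(S(=O)(=O)Oc3ccccc3C)cc2)C1=O`: a limit, > 100000 nM

The three compounds above were tested in a functional assay on HT-29 cells (Homo sapiens) for antiproliferative activity, read by sulforhodamine B assay, with a stated time of 48 h; a lower number here means a stronger inhibitor, a higher number a weaker inhibitor. Compound 1 gives 12000 nM, and the change to compound 2, (methyl in place of hydrogen on a saturated chain carbon bound to an amide-type nitrogen in a ring), brings a 3.1-fold higher number from compound 1 to compound 2 (0.49 log units; beyond the scatter). For compound 3 the result is only a limit, > 100000 nM. The difference between the core of compound 1 and the core of compound 3 is not broken down here.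

Compound 4 `CCCN1CCN(c2ccc(S(=O)(=O)Oc3ccccc3CC)cc2)C1=O` has not yet been measured in this assay. Within the data shown here, its change from compound 3, (methyl in place of hydrogen on a saturated chain carbon bound to an aromatic carbon), is the same kind of change as the one from compound 1 to compound 2, but at a different place: on a saturated chain carbon bound to an aromatic carbon rather than on a saturated chain carbon bound to an amide-type nitrogen in a ring. Because compound 3 already sits at the limit of > 100000 nM in this assay, at which 1 of the 3 values shown sits, compound 4 is expected to remain near that limit, so the step that the limit leaves unreadable from compound 3 to compound 4 is estimated to be small. Compound 4 is therefore expected to give about 150000 nM, within roughly 60000 nM to 400000 nM.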

Compound 4, half-maximal inhibitory concentration: > 100000 nM
Compound 4 ended at the assay's limit; the forecaster's own chance of this, stated with the estimate: 75%; the middle value lies beyond the limit too.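

Compound 3 and compound 4 both end at a limit rather than a number, and the step between them cannot be read. The compounds shown leave open whether going from 2-methylphenyl to 2-ethylphenyl changes antiproliferative activity at all.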